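Dimethylphenyl Replaces Chlorophenyl on a Triazole Nitrogen

The source may hold more compounds than are shown below. What is called first, only, known or untested is meant among the compounds shown, and "the series" means these compounds.

Compound 3 `O=C(NO)c1ccc(NCc2nc(-c3ccccc3)nn2-c2ccc(Cl)cc2)cc1` was measured in an assay on Sf9 cells for inhibition of protein deacetylase HDAC6 (Homo sapiens), read by fluorescence, with a stated time of 40 min, tested at 100 nM (on this read-out higher numbers stand for more inhibition at the one concentration tested (going by the name of the read-out) and lower numbers for less inhibition), where compound 3 gives 55.4%. Its number is the lowest of the three shown: compound 1 `O=C(NO)c1ccc(NCc2nc(-c3ccccc3)nn2-c2cccc(Cl)c2)cc1` gives 62.3%, and compound 2 `O=C(NO)c1ccc(NCc2nc(-c3ccccc3)nn2-c2ccccc2)cc1` gives 72.6%. The largest gap is a number 17.2 percentage points lower from compound 2 to compound 3 (beyond the scatter), whereas a number 6.9 percentage points lower from compound 1 to compound 3 (within the scatter) lies within the scatter; the remaining step, a number 10.3 percentage points higher from compound 1 to compound 2 (beyond the scatter), is beyond it.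

Compound 4 `Cc1ccc(-n2nc(-c3ccccc3)nc2CNc2ccc(C(=O)NO)cc2)cc1C` differs from compound 3 in one place: 3,4-dimethylphenyl in place of 4-chlorophenyl on an aromatic nitrogen. For the measured compounds named here, no measured step exchanges a chlorophenyl for a dimethylphenyl, so the known steps bear on it only loosely. They show that hydrogen in place of chloro on an aromatic carbon moved the read-out by a number 10.3 percentage points higher from compound 1 to compound 2 (beyond the scatter), and chloro in place of hydrogen by a number 17.2 percentage points lower from compound 2 to compound 3 (beyond the scatter), both modest. A step of similar size in either direction is therefore plausible, and a small upward lean is the more defensible guess. Compound 4 is expected to give 60% in this assay, with a range from 42% to 78%. This corresponds to an expected step of a number 4.6 percentage points higher from compound 3 to compound 4 (within the scatter).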

Compound 4, a percentage reported as inhibition, at one concentration (the size of the read-out at that concentration, not a potency): 53%
Beside the measured number, compound 4's estimate is 7 percentage points above it; low and high end bracket the measured number.
By their numbers in this assay, from the lowest: compounds 4, 3 and 1 (each within the scatter of the next); then compound 2.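

With a number 2.4 percentage points lower from compound 3 to compound 4 (within the scatter) and with a number 9.3 percentage points lower from compound 1 to compound 4 (within the scatter) in this assay the 3,4-dimethylphenyl group on the aromatic nitrogen cannot be told apart from either chlorophenyl group, so exchanging chloro for two methyl groups on this ring makes no readable difference. For the compounds shown here, the unsubstituted phenyl group still stands apart, with a number 19.6 percentage points lower from compound 2 to compound 4 (beyond the scatter) as the largest step seen so far, and all three substituted rings in this small set now read beyond the scatter below it, with no compound going against that. Nothing available explains why these substituents give this result.

From the compounds shown here alone, it remains open whether a single methyl group on this ring would read with phenyl or with the substituted rings. Going by these compounds, the effect of an amine or a carboxylic acid on the ring, or of cyclohexyl in place of the whole aromatic ring, also remains unknown.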